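Trifluoromethyl for methyl on the core of compound 2

The source may hold more compounds than are shown below. What is called first, only, known or untested is meant among the compounds shown, and "the series" means these compounds.

Measured so far:
compound 1, `CSc1ccc(C)cc1NCC1=NCCN1`, 81%
compound 2, `Cc1ccc(S(C)(=O)=O)c(NCC2=NCCN2)c1`, 76%
compound 3, `CSc1ccc(Cl)cc1NCC1=NCCN1`, 92%

Compound 2 gives the lowest of the three numbers in a functional assay on CHO cells for agonist activity at Alpha-2C adrenergic receptor (Homo sapiens); a higher number here means a larger maximal response, a lower number a smaller maximal response. Its nearest neighbour is compound 1, whose value lies within the scatter of it, as a number 5 percentage points lower from compound 1 to compound 2 (within the scatter) shows; compound 3 stands furthest away, beyond the scatter.

The unmeasured compound 4, `CS(=O)(=O)c1ccc(C(F)(F)F)cc1NCC1=NCCN1`, differs from compound 2 in one place: trifluoromethyl in place of methyl on an aromatic carbon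

For the measured compounds named here, one measured step bears on this change. From compound 1 to compound 3 a chloro replaced a methyl on the same aromatic carbon, para to a methylsulfanyl group, and the maximal response moved by a number 11 percentage points higher from compound 1 to compound 3 (beyond the scatter). The step from compound 1 to compound 2, a number 5 percentage points lower from compound 1 to compound 2 (within the scatter), shows that exchanging methylsulfanyl for methylsulfonyl leaves the response within the scatter, so the chloro step is taken as the guide. Going by the values given here, an increase of similar, modest size is therefore expected for the trifluoromethyl, though no measured pair shows a trifluoromethyl itself. The expected step is a number 8 percentage points higher from compound 2 to compound 4 (within the scatter). Compound 4 is thus estimated at 84%, with a range from 70% to 97%.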

Compound 4, largest response reached (reported as maximum), in percent of the reference or control that the assay uses: 25%
The estimate for compound 4 lay 59 percentage points above the measured number; the whole stated range lies above it.
By their numbers in this assay, from the lowest: compound 4; then compounds 2 and 1 (each within the scatter of the next); then compound 3.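

In this assay, for the compounds shown here, the aromatic carbon para to a methylsulfonyl group proves far less forgiving than the earlier compounds suggested: trifluoromethyl in place of methyl gives a number 51 percentage points lower from compound 2 to compound 4 (beyond the scatter). The only earlier replacement of methyl on this carbon, a number 11 percentage points higher from compound 1 to compound 3 (beyond the scatter), was modest and went the other way, so a change here can shift the maximal response strongly in either direction, depending on the group that enters, the group para to it, or both. Nothing measured here accounts for the size of this drop, which comes with three fluorine atoms entering and no change in ring, hydrogen-bond donors, hydrogen-bond acceptors or net charge.

The compounds shown do not separate the trifluoromethyl from its partner, since only the methylsulfonyl series carries it and only the methylsulfanyl series carries chloro, so it remains open whether trifluoromethyl para to methylsulfanyl would fall as far, or chloro para to methylsulfonyl would rise. Also open, from the compounds shown here alone, is how other groups on this carbon, such as an ethyl, a methoxy or a nitrile, would behave alongside the methylsulfonyl group.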